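The source may hold more compounds than are shown below. What is called first, only, known or untested is meant among the compounds shown, and "the series" means these compounds.

In an ADME assay on a cell-free system (plasma, Rattus norvegicus) for protein binding (on this read-out higher numbers stand for a larger free fraction and lower numbers for a smaller free fraction), compound 1 `COCC(C1CC1)n1c(=O)c(C)nc2c(-c3cc(F)c(OC)cc3Cl)ccnc21` gives < 0.002, which is a limit of the assay and not a number. Compound 1 therefore stands at the limit of < 0.002 in this assay, at which 1 of the 2 values shown sits. Compound 2 `CC[C@@H](C1CC1)n1c(=O)c(C)nc2c(-c3ccc(Cl)cc3Cl)ccnc21` reads 0.002. Compound 3 `CCC(COC)n1c(=O)c(C)nc2c(-c3cc(F)c(OC)cc3Cl)ccnc21` carries ethyl in place of cyclopropyl on a saturated chain carbon bound to an aromatic nitrogen and a saturated chain carbon. Going by the values given here, no measured step bears on this change, so no shift beyond the scatter in this assay is expected, and any small shift is expected upward. The expected step is a number no lower from compound 1 to compound 3 (the limit leaves the size open). For compound 3 the estimated value is 0.002, with an expected range of 0.001 to 0.005.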

Compound 3, unbound fraction: 0.03
For compound 3 the middle estimate is 15-fold (1.18 log units) below the measured one; measured number above the stated range.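

On the saturated chain carbon bound to an aromatic nitrogen and a saturated chain carbon, ethyl in place of cyclopropyl gives an at least 15-fold higher number from compound 1 to compound 3 (1.17 log units; beyond the scatter) in this assay. Going by these compounds alone, this is the first change at this position that can be read, and it shows that the unbound fraction responds to this exchange. The step starts from a limit of the assay and not a number, so its full size stays open: the limit of < 0.002 in this assay, at which 1 of the 3 values shown sits.

As far as these compounds go, whether the same exchange would hold in compound 2 remains open. From the compounds shown here alone, how a longer chain such as propyl, or an amine, would read at this position also remains open.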